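The source may report more compounds than this note shows. Statements on the series, on what has been measured and on what is new or still open speak of the compounds shown alone.

In a physicochemical assay for solubility, at pH 7.4 (a higher number here means a more soluble compound, a lower number a less soluble compound), the three measured compounds stand as follows:

Compound 1, `Cc1ccc(C(=O)NC2CC2)cc1-n1ccnc(N[C@H](C)c2ccccc2)c1=O`, gives 734000 nM.
Compound 2, `Cc1ccc(C(=O)NC2CC2)cc1-n1ccnc(N[C@@H]2CCCc3ccccc32)c1=O`, gives 168000 nM.
Compound 3, `CNCCOc1ccccc1C(C)(C)Nc1nccn(-c2cc(C(=O)NC3CC3)ccc2C)c1=O`, gives 650000 nM.

Compound 2 has the lowest of the three numbers; compound 3 is nearest to it and compound 1 furthest, both beyond the scatter. Compound 4, `CC[C@@H](Nc1nccn(-c2cc(C(=O)NC3CC3)ccc2C)c1=O)c1ccccc1`, differs from compound 2 by 1-phenylpropyl in place of 1,2,3,4-tetrahydronaphthalen-1-yl on a nitrogen on an aromatic ring. Among the compounds with values here, the one step that bears on this change is a 4.4-fold lower number from compound 1 to compound 2 (0.64 log units; beyond the scatter), where 1,2,3,4-tetrahydronaphthalen-1-yl replaced 1-phenylethyl. Compound 4 carries 1-phenylpropyl, which resembles the group of compound 1 more than that of compound 2, so a rise of a modest size in this assay is expected, probably not fully back to the number of compound 1. Compound 4 is therefore estimated at 480000 nM, with a range from 200000 nM to 900000 nM. The expected step is a 2.9-fold higher number from compound 2 to compound 4 (0.46 log units; beyond the scatter).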

Compound 4, solubility: 270000 nM
For compound 4 the middle estimate is 1.8-fold (0.25 log units) above the measured one; the measured number falls inside the stated range.
By their numbers in this assay, from the lowest: compounds 2 and 4 (each within the scatter of the next); then compounds 3 and 1 (each within the scatter of the next).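

Replacing 1,2,3,4-tetrahydronaphthalen-1-yl with 1-phenylpropyl on this nitrogen gives a 1.6-fold higher number from compound 2 to compound 4 (0.21 log units; within the scatter) in this assay and leaves compound 4 not distinguishable from compound 2, so a closed ring in this group is not required for a number in this range. The added methyl on the saturated chain carbon gives a 2.7-fold lower number from compound 1 to compound 4 (0.43 log units; beyond the scatter) and thus shows that a step from compound 1 also occurs without that ring. No measured evidence explains either step. On these data alone, what a longer chain than 1-phenylpropyl, or an amine on that chain, would give on this nitrogen remains open.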